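Ethoxycarbonyl to acetyl on the shared core

The compounds below may be only part of what the source reports. "The series", "measured", "known", "first", "only" and "open" are said of these compounds alone.

Measured so far:
compound 1 `C=C(C)[C@@H]1CC=C(Cn2cc(COc3cccc(C4NC(=O)NC(C)=C4C(=O)OCC)c3)nn2)CC1` — > 100000 nM
compound 2 `C=C(C)[C@@H]1CC=C(Cn2cc(COc3ccccc3C3NC(=O)NC(C)=C3C(=O)OCC)nn2)CC1` — > 100000 nM
compound 3 `C=C(C)[C@@H]1CC=C(Cn2cc(COc3cccc(C4NC(=O)NC(C)=C4C(C)=O)c3)nn2)CC1` — > 100000 nM

In a functional assay on NCI-H460 cells (Homo sapiens) for inhibition, read by sulforhodamine B assay, with a stated time of 48 h (a lower number here means a stronger inhibitor of growth, a higher number a weaker inhibitor of growth), compound 1 gives only a limit of the assay, > 100000 nM, not a number. Compound 2 likewise stops at the limit, > 100000 nM. Compound 3 also reaches only the limit, > 100000 nM. Taken together this is the limit of > 100000 nM in this assay, at which 3 of the 3 values shown sit.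

Compound 1 and compound 3 differ in one place: methyl in place of ethoxy on a carbonyl carbon. The step that the two limits leave unreadable from compound 1 to compound 3 cannot be sized because the limit of > 100000 nM in this assay, at which 3 of the 3 values shown sit, covers both ends of it.

The difference between the core of compound 1 and the core of compound 2 is not broken down here.

Compound 4 `C=C(C)[C@@H]1CC=C(Cn2cc(COc3ccccc3C3NC(=O)NC(C)=C3C(C)=O)nn2)CC1` is not yet measured. It differs from compound 2 by methyl in place of ethoxy on a carbonyl carbon, the same change as from compound 1 to compound 3, made at the same kind of place.

The step from compound 2 to compound 4 in this assay is expected to be a step that the limit leaves unreadable from compound 2 to compound 4, resting on compound 2 sitting at the limit of > 100000 nM in this assay, at which 3 of the 3 values shown sit, and on a step that the two limits leave unreadable from compound 1 to compound 3 being unreadable. Compound 4 is estimated at 150000 nM, between 50000 nM and 600000 nM, most likely again only a limit.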

Compound 4, concentration for total growth inhibition: 83100 nM
Compound 4: the middle estimate sits 1.8-fold (0.26 log units) above what was measured, and the stated range covers the measured number.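

In this assay, ethoxycarbonyl to acetyl on the core of compound 2 gives an at least 1.2-fold lower number from compound 2 to compound 4 (0.08 log units; that floor lies within the scatter), so this step alone does not establish a real gain. Compound 4 does give a number, 83100 nM, and that number provides a measured reference point for this core, though it says nothing further about the size of the step. The same change on the core of compound 1 cannot be read, and whether the change carries from one core to the other stays untested, because the values at both ends of that step and the starting value here are limits of the assay, not numbers: the limit of > 100000 nM in this assay, at which 3 of the 4 values shown sit.

The compounds shown leave open whether an amine or a hydroxyl on the carbonyl carbon, giving an amide or a carboxylic acid, would bring a value clear of the limit. They also leave open what a longer chain, such as propyl, would do in place of the methyl of the acetyl group.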